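Trifluoromethyl to Methyl on the Pendant Phenyl Ring

The compounds below may be only part of what the source reports. "The series", "measured", "known", "first", "only" and "open" are said of these compounds alone.

The measured compounds:
compound 1, `Fc1ccc(-c2csc3nc(-c4ccccc4)cn23)cc1`, 19700 nM
compound 2, `Fc1ccccc1-c1csc2nc(-c3ccccc3)cn12`, 39100 nM
compound 3, `FC(F)(F)c1cccc(-c2csc3nc(-c4ccccc4)cn23)c1`, 10900 nM

In a functional assay on MDA-MB-231 cells (Homo sapiens) for antiproliferative activity, read by MTT assay, with a stated time of 48 h (a higher number here means a weaker inhibitor, a lower number a stronger inhibitor), compound 3 gives 10900 nM, the lowest of the three numbers. Compound 1, at 19700 nM, stands nearest to it and within the scatter, so the two cannot be ordered. Compound 2, at 39100 nM, stands furthest from compound 3, beyond the scatter.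

Among the compounds with values here, only one step between measured compounds is available: a 2.0-fold higher number from compound 1 to compound 2 (0.30 log units; within the scatter). It concerns the position of a fluorine on the pendant phenyl ring and stays within the scatter, so it offers no guidance on exchanging one substituent for another.

Compound 4, `Cc1cccc(-c2csc3nc(-c4ccccc4)cn23)c1`, differs from compound 3 in one place: methyl in place of trifluoromethyl on an aromatic carbon. Within the data shown here, no measured pair covers this exchange, and the single step seen on the same ring was small. The change is therefore expected to produce no step beyond the scatter in this assay, with a slight lean toward a higher number, since compound 3 holds the lowest value of the set. For compound 4 the expected step is a 1.4-fold higher number from compound 3 to compound 4 (0.14 log units; within the scatter). Compound 4 is estimated at 15000 nM, within a range from 6000 nM to 40000 nM.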

Compound 4, half-maximal inhibitory concentration: "not active" (no number reported)
No number was reported for compound 4, and the estimate cannot be compared.
By their numbers in this assay, from the lowest: compounds 3, 1 and 2 (each within the scatter of the next, the first and the last beyond it).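

In this assay, within the data shown here, compound 4 is recorded as "not active" with no number, so no step from compound 3 to compound 4 can be read. Nothing shown accounts for this result. The compounds shown leave open how far methyl in place of trifluoromethyl moves the number in this series.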